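Flipping Configuration on a Lactam-Bearing Compound

The source may hold more compounds than are shown below. What is called first, only, known or untested is meant among the compounds shown, and "the series" means these compounds.

In a functional assay on OPM-2 cells (Homo sapiens) for antiproliferative activity, read by CCK-8 assay, with a stated time of 5 days (on this read-out higher numbers stand for weaker inhibition and lower numbers for stronger inhibition), compound 1 `COc1ccc(CCc2nc3cc(-c4c(C)noc4C)ccc3n2[C@H]2CC[C@H](OC)CC2)cc1Cl` gives 2290 nM and compound 2 `COc1ccc(CCc2nc3cc(-c4c(C)noc4C)ccc3n2[C@H]2CC[C@H](O)CC2)cc1Cl` gives 1390 nM. Compound 3 `COc1ccc(N2C(=O)C[C@H]2c2nc3cc(-c4c(C)noc4C)ccc3n2[C@H]2CC[C@H](OC)CC2)cc1Cl` gives 1090 nM, within the scatter of compound 2 and beyond the scatter below compound 1. Compound 4 `COc1ccc(N2C(=O)C[C@@H]2c2nc3cc(-c4c(C)noc4C)ccc3n2[C@H]2CC[C@H](OC)CC2)cc1Cl` has the same atoms and bonds as compound 3 and differs only in configuration as drawn: the two compounds have the same atoms and bonds and differ only in configuration as drawn: 2 of 3 stereo elements differ; a stereocentre at a saturated ring carbon is drawn S in compound 3 and R in compound 4; a stereocentre at a saturated ring carbon is drawn S in compound 3 and R in compound 4. Among the compounds with values here, the only measured step is a 1.6-fold lower number from compound 1 to compound 2 (0.22 log units; within the scatter), which swaps a group and leaves configuration untouched, so no measured pair tests this kind of change. A cautious expectation is therefore a modest rise, with wide uncertainty. The expected step is a 2.3-fold higher number from compound 3 to compound 4 (0.36 log units; beyond the scatter). For compound 4 the estimated value is 2500 nM, with an expected range of 700 nM to 8000 nM.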

Compound 4, half-maximal inhibitory concentration: 1540 nM
Compound 4: middle estimate off by 1.6-fold (0.21 log units), on the high side; the measured number falls inside the stated range.
By their numbers in this assay, from the lowest: compounds 3, 2, 4 and 1 (each within the scatter of the next, the first and the last beyond it).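

Within the data shown here, this is the first step where only configuration changes, and the comparison is clean because nothing else separates the pair: the fact that compounds 3 and 4 differ only in the configuration as drawn Drawing two of the three stereo elements the other way gives a 1.4-fold higher number from compound 3 to compound 4 (0.15 log units; within the scatter) in this assay. At these two stereocentres, then, this read-out shows no clear preference between the two arrangements.

From the compounds shown here alone, both stereocentres change together, so the effect of each one alone remains unknown. Also open, going by these compounds, is how either form would read with an amine or a carboxylic acid in place of the methoxy group on the saturated carbon.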